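A few compounds are considered here, and "the series" means these few. Any claim that something is new, unique, unknown or untested is made for them only; others in the source may bear on it.

Measured compounds in a functional assay on B16 cells (Mus musculus) for cytotoxicity, read by MTT assay, with a stated time of 48 h; on this read-out lower numbers stand for stronger inhibition and higher numbers for weaker inhibition:

Compound 1 `Cc1ccc(C(O)c2cn(CC3COC(C)(C)O3)nn2)cc1` — compound 1 gives > 100000 nM, which is a limit of the assay and not a number.
Compound 2 `Cc1ccc(C(O)c2cn(Cc3ccccc3)nn2)cc1` — compound 2 gives > 100000 nM, again a limit of the assay.
Compound 3 `OC(c1ccc(C(F)(F)F)cc1)c1cn(Cc2ccccc2)nn1` — compound 3 gives > 100000 nM, also a limit of the assay.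

Compound 3 therefore stands nowhere on a scale of numbers: its value in this assay is a limit, and the two other values shown are limits as well (the limit of > 100000 nM in this assay, at which 3 of the 3 values shown sit). The step to compound 4 `CC1(C)OCC(Cn2cc(C(O)c3ccc(C(F)(F)F)cc3)nn2)O1` is 2,2-dimethyl-1,3-dioxolan-4-yl in place of phenyl on a saturated chain carbon bound to an aromatic nitrogen. Of the measured steps, a step that the two limits leave unreadable from compound 1 to compound 2 covers the same exchange in the opposite direction, and a step that the two limits leave unreadable from compound 2 to compound 3 links the two aryl substituents; neither can be read, since both ends sit at the limit (the limit of > 100000 nM in this assay, at which 3 of the 3 values shown sit). Within the measured compounds nothing shows any change beyond the scatter, and nothing shows a change at all. The expectation for compound 4 in this assay is thus no readable step that the limit leaves unreadable from compound 3 to compound 4, most likely another limit. Compound 4 is estimated at 150000 nM, with a range from 50000 nM to 500000 nM.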

Compound 4, half-maximal inhibitory concentration: > 100000 nM
Compound 4 ended at the assay's limit (the forecaster's own chance of this, stated with the estimate: 85%); the middle value lies beyond the limit too.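

Neither the step from compound 3 to compound 4 nor the step from compound 1 to compound 4 can be read, as both ends of each are limits and not numbers: the limit of > 100000 nM in this assay, at which 4 of the 4 values shown sit.

The compounds shown leave open whether trifluoromethyl versus methyl, or benzyl versus (2,2-dimethyl-1,3-dioxolan-4-yl)methyl, makes any difference in this assay.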